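The source may hold more compounds than are shown below. What is called first, only, known or untested is meant among the compounds shown, and "the series" means these compounds.

Compound 1 `COc1cc(CC[C@@H](O)C[C@@H](O)CCc2ccc(O)cc2)ccc1O` gives 2810 nM in a functional assay on RAW264.7 cells (Mus musculus) for inhibition, read by spectrophotometry and Griess assay, with a stated time of 24 h; a higher number here means a weaker inhibitor, a lower number a stronger inhibitor. Compound 2 `CC(=O)O[C@H](CCc1ccc(O)cc1)C[C@H](O)CCc1ccc(O)cc1` gives 32000 nM. Compound 3 `Oc1ccc(CC[C@@H](O)C[C@H](O)CCc2ccc(O)cc2)cc1` gives > 100000 nM, which is a limit of this assay rather than a number.

Compound 3 therefore stands at the weak end of what this assay can report. Going by the values given here, the only measured step, an at least 3.1-fold higher number from compound 2 to compound 3 (0.49 log units; beyond the scatter), concerns a substituent on an oxygen, not a configuration, so it does not bear on the present change. Compound 4 `Oc1ccc(CC[C@@H](O)C[C@@H](O)CCc2ccc(O)cc2)cc1` differs from compound 3 as follows: the two compounds have the same atoms and bonds and differ only in configuration as drawn: 1 of 2 stereo elements differ; a stereocentre at a saturated chain carbon is drawn R in compound 3 and S in compound 4. As far as these compounds go, no measured step sizes a change of configuration here, and because compound 3 sits at the limit of > 100000 nM in this assay, at which 1 of the 3 values shown sits, the starting point itself is unknown. Compound 4 is expected to give 20000 nM (range 3000 nM to 100000 nM). The expected step is an at least 5.0-fold lower number from compound 3 to compound 4 (0.69 log units; beyond the scatter), with wide uncertainty.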

Compound 4, half-maximal inhibitory concentration: > 100000 nM
Compound 4: only a limit was reported; the forecaster's own chance of this, stated with the estimate: 35%; middle value at least 5.0-fold (0.69 log units) from the limit.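

In this assay, hydrogen in place of methoxy on an aromatic carbon gives a large loss (an at least 35-fold higher number from compound 1 to compound 4 (1.55 log units; beyond the scatter)), so this position on the core of compound 1 does not tolerate losing the methoxy. The step between compound 3 and compound 4 cannot be read, so the effect of the drawn configuration at the chain carbon stays unsized: the limit of > 100000 nM in this assay, at which 2 of the 4 values shown sit. The comparison concerns configuration alone: the fact that compounds 3 and 4 differ only in the configuration as drawn.

As far as these compounds go, whether an ethoxy group or a longer alkoxy chain on the same aromatic carbon would hold the strength of compound 1 remains open. Also open, from the compounds shown here alone, is how that chain carbon's configuration behaves with the methoxy in place.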